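Swapping the Indole Amide Cap for an Isoxazole Cap

The source may report more compounds than this note shows. Statements on the series, on what has been measured and on what is new or still open speak of the compounds shown alone.

Compound 1 `Cc1ccc2[nH]c(C(=O)N[C@H]3CN(S(=O)(=O)c4ccccc4)C[C@@H]3C(=O)NC[C@@H]3CCCN3C)cc2c1`: 31 mL.min-1.g-1
Compound 2 `Cc1ccc2[nH]c(C(=O)N[C@H]3CN(S(=O)(=O)c4ccccc4)C[C@@H]3C(=O)N[C@@H]3CCCNC3)cc2c1`: 3 mL.min-1.g-1
Compound 3 `Cc1ccc2[nH]c(C(=O)N[C@H]3CN(S(=O)(=O)c4ccccc4)C[C@@H]3C(=O)N[C@H]3CCCNC3)cc2c1`: < 3 mL.min-1.g-1

In an ADME assay on microsomes from liver (Homo sapiens) for metabolic stability (on this read-out lower numbers stand for slow clearance and higher numbers for fast clearance), compound 1 gives 31 mL.min-1.g-1 and compound 2 gives 3 mL.min-1.g-1. For compound 3 this assay reports only a limit, < 3 mL.min-1.g-1, so compound 3 sits at the slow end of the numbers shown (the limit of < 3 mL.min-1.g-1 in this assay, at which 1 of the 3 values shown sits). Compound 4 `O=C(N[C@H]1CN(S(=O)(=O)c2ccccc2)C[C@@H]1C(=O)N[C@H]1CCCNC1)c1cc(-c2ccccc2Cl)on1` differs from compound 3 by a group of 12 heavy atoms (9 carbon, 1 nitrogen, 1 oxygen, 1 chlorine; one five-membered aromatic ring with 2 hetero atoms, one six-membered aromatic ring of carbon only) in place of a group of 10 heavy atoms (9 carbon, 1 nitrogen; one five-membered aromatic ring with 1 hetero atom, one six-membered aromatic ring of carbon only), on a carbonyl carbon. The measured steps, a 10-fold lower number from compound 1 to compound 2 (1.01 log units; beyond the scatter), an at least 10-fold lower number from compound 1 to compound 3 (1.01 log units; beyond the scatter) and a number no higher from compound 2 to compound 3 (the limit leaves the size open), all concern the other amide-type nitrogen, so none of them bears on this change. Compound 4 is therefore expected to stay near compound 3, an at least 1.6-fold higher number from compound 3 to compound 4 (0.22 log units; that floor lies within the scatter), with an estimate of 5 mL.min-1.g-1 ranging from 2 mL.min-1.g-1 to 20 mL.min-1.g-1.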

Compound 4, intrinsic clearance in microsomes: < 3 mL.min-1.g-1
Compound 4 was reported as a limit (the forecaster's own chance of this, stated with the estimate: 35%); at least 1.6-fold (0.22 log units) between middle value and limit.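

Compound 3 and compound 4 are both reported only as limits in this assay, so the step between them cannot be read. The compounds shown leave open whether replacing the 5-methyl-1H-indol-2-yl group changes clearance at all.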